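Replacing methoxymethyl with phenoxy on a side chain

The source may hold more compounds than are shown below. What is called first, only, known or untested is meant among the compounds shown, and "the series" means these compounds.

Of the compounds shown here, three sharing one core have been measured in a functional assay on RAW264.7 cells (Mus musculus) for inhibition, read by Griess assay, with stated times of 1 h and 24 h; a higher number here means a weaker inhibitor, a lower number a stronger inhibitor. Compound 1 `CCCOc1ccc(C(O)C2OC(=O)c3c(OC)cc(OC)cc32)cc1` gives 9260 nM, compound 2 `CCCCCCOc1ccc(C(O)C2OC(=O)c3c(OC)cc(OC)cc32)cc1` gives 5360 nM, and compound 3 `COCCCOc1ccc(C(O)C2OC(=O)c3c(OC)cc(OC)cc32)cc1` gives 1260 nM, the lowest number of the three and so the strongest inhibitor among them.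

The unmeasured compound 4 `COc1cc(OC)c2c(c1)C(C(O)c1ccc(OCCOc3ccccc3)cc1)OC2=O` alters the chain of compound 3: phenoxy in place of methoxymethyl on a saturated chain carbon, two bonds along the chain from an oxygen on an aromatic ring. Phenoxy stands in place of methoxymethyl on a saturated chain carbon, two bonds along the chain from an oxygen on an aromatic ring.

Three measured steps on this chain bear on the change. Propyl in place of hydrogen gave a 1.7-fold lower number from compound 1 to compound 2 (0.24 log units; within the scatter). Methoxy in place of hydrogen gave a 7.3-fold lower number from compound 1 to compound 3 (0.87 log units; beyond the scatter), and methoxy in place of propyl gave a 4.3-fold lower number from compound 2 to compound 3 (0.63 log units; beyond the scatter). For the measured compounds named here, compound 3 is thus the only measured compound with a methoxy group on the chain, and it stands apart from the other two. Going by the values given here, no measured compound carries a ring on the chain, so phenoxy has not been tested directly, and the estimate is loose.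

Part of the advantage of compound 3 is expected to be lost, giving a 2.4-fold higher number from compound 3 to compound 4 (0.38 log units; beyond the scatter), a modest move towards a weaker inhibitor. Compound 4 is estimated at 3000 nM, with an expected range from 900 nM to 10000 nM.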

Compound 4, half-maximal inhibitory concentration: > 10000 nM
Compound 4: a limit, no number (the forecaster's own chance of this, stated with the estimate: 5%); middle value at least 3.3-fold (0.52 log units) from the limit.
By their numbers in this assay, from the lowest: compound 3; then compounds 2 and 1 (each within the scatter of the next). At a limit, above all of these: compound 4.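

In this assay compound 4 gives > 10000 nM, which is a limit of the assay and not a number. Even read as a floor, the change gives an at least 7.9-fold higher number from compound 3 to compound 4 (0.89 log units; beyond the scatter), so on a saturated chain carbon, two bonds along the chain from an oxygen on an aromatic ring, phenoxy does not keep the low number that compound 3 has with methoxymethyl, although each group holds one oxygen and one hydrogen-bond acceptor, so that count alone does not preserve it. The other two floors, an at least 1.8-fold higher number from compound 2 to compound 4 (0.27 log units; that floor lies within the scatter) and an at least 1.0-fold higher number from compound 1 to compound 4 (0.03 log units; that floor lies within the scatter), lie within the scatter, so these figures do not separate compound 4 from the two compounds without a chain oxygen.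

As far as these compounds go, the swap from 3-methoxypropoxy to 2-phenoxyethoxy alters both the chain and its end group at once, so it remains open whether the six-membered aromatic ring or the different chain matters more. A 3-phenoxypropoxy chain or a 2-methoxyethoxy chain would pull these two apart, and an amine at the chain end would test a different kind of end group.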